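Replacing a benzamido with a 4-(tert-butyl)phenoxy group

A few compounds are considered here, and "the series" means these few. Any claim that something is new, unique, unknown or untested is made for them only; others in the source may bear on it.

Measured compounds:
compound 1, `Nc1ncnc2c1c(-c1ccc(NC(=O)c3ccccc3)cc1)cn2[C@H]1CCN(C[C@@H]2CO2)C1`, 3180 nM
compound 2, `Nc1ncnc2c1c(-c1cc3ccccc3o1)cn2[C@H]1CCN(C[C@@H]2CO2)C1`, 4510 nM

Of the compounds shown here, two built on the same core have been measured in a functional assay on Daudi cells (Homo sapiens) for antiproliferative activity; a lower number here means a stronger inhibitor, a higher number a weaker inhibitor. Compound 1 gives 3180 nM, the lowest of the two numbers, and compound 2 gives 4510 nM, a number that lies within the scatter of compound 1, so the two are not separated by this assay.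

Compound 3, `CC(C)(C)c1ccc(Oc2ccc(-c3cn([C@H]4CCN(C[C@@H]5CO5)C4)c4ncnc(N)c34)cc2)cc1`, has not yet been measured in this assay. It differs from compound 1 in one place: 4-(tert-butyl)phenoxy in place of benzamido on an aromatic carbon. The group that enters sits on the same aromatic carbon, para to a large group, and carries no hydrogen-bond donor where the benzamido carried one.

Among the compounds with values here, no step between measured compounds is available, so there is no guide for the size of this change. Given that compound 1 starts from 3180 nM, a modest move toward a lower number is expected from compound 1 to compound 3, a 2.1-fold lower number from compound 1 to compound 3 (0.33 log units; beyond the scatter), though a step that stays within the scatter would not be surprising. Compound 3 is estimated at 1500 nM in this assay, within a range of 300 nM to 8000 nM.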

Compound 3, half-maximal inhibitory concentration: 6490 nM
The estimate for compound 3 lay 4.3-fold (0.64 log units) below the measured number, within the range that was stated.
By their numbers in this assay, from the lowest: compounds 1, 2 and 3 (each within the scatter of the next, the first and the last beyond it).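

In this assay, within the data shown here, the exchange of benzamido for 4-(tert-butyl)phenoxy on this aromatic carbon, para to a large group, gives a 2.0-fold higher number from compound 1 to compound 3 (0.31 log units; beyond the scatter) and is the only step between measured compounds that can be read here. It shows that the activity of this series responds to the group at this position, and that this particular exchange, which removes the hydrogen-bond donor of the benzamido, moves toward a weaker inhibitor rather than a stronger one. Nothing available bears on what lies behind this step.

Among these compounds, the single step leaves open whether the change follows from losing the amide hydrogen, from the ether oxygen or from the tert-butyl group, since all of these differ at once between compound 1 and compound 3. An unsubstituted phenoxy group, or a benzamido carrying a methyl group on its nitrogen, on the same aromatic carbon would begin to separate these parts, and the compounds shown give no reading for either.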